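Swapping a Chlorophenyl for a Methylpyridyl on the Piperidine-free Core

The source may hold more compounds than are shown below. What is called first, only, known or untested is meant among the compounds shown, and "the series" means these compounds.

Compound 1 `Cc1cccc(NC(=O)CN2CCC(c3ccc(Cl)cc3)CC2)c1` is the starting point of this step. In a functional assay on cells for agonist activity at D(4) dopamine receptor (Homo sapiens), read by TR-FRET and cAMP accumulation, with a stated time of 30 min (a higher number here means that more compound is needed for the effect, a lower number that less compound is needed), compound 1 is recorded as "not active" (no number reported), so no single number places it on the scale. Two related compounds give numbers: compound 2 `O=C(CN1CCN(c2ccccn2)CC1)Nc1cccnc1` gives 1080 nM in this assay, and compound 3 `CCc1cccc(NC(=O)CN2CCN(c3ccccn3)CC2)c1` gives 28.7 nM. For the measured compounds named here, the one measured step, a 38-fold lower number from compound 2 to compound 3 (1.58 log units; beyond the scatter), concerns the group on the amide-type nitrogen and leaves the rest of the core untouched.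

Compound 4 `Cc1ccc(C2CCN(CC(=O)Nc3cccc(C)c3)CC2)nc1` differs from compound 1 at a different place: 5-methylpyridin-2-yl in place of 4-chlorophenyl on a saturated ring carbon. No measured step changes the group on the saturated ring carbon, so the size of the effect of this exchange has no direct precedent among the compounds shown. Going by the values given here, the only guidance is that the core with a pyridine ring attached can reach a low number, as compound 3 shows, while compound 1 itself produced no number at all.

The estimate for compound 4 in this assay therefore rests on little and is wide: the expected value is 800 nM, with a range from 60 nM to 10000 nM, and a real chance that again only a limit is returned.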

Compound 4, half-maximal effective concentration: "not active" (no number reported)
For compound 4 the study gives words and no number; the estimate stays without a comparison.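

Compound 1 and compound 4 both return words and no number in this assay, so no step can be read between them. The compounds shown leave open what the exchange of 4-chlorophenyl for 5-methylpyridin-2-yl on the saturated ring carbon does on this scale. Nothing further shown here bears on this result.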